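Amide variation on the shared core: compound 3 to compound 4

A few compounds are considered here, and "the series" means these few. Any claim that something is new, unique, unknown or untested is made for them only; others in the source may bear on it.

Measured so far in a functional assay on A375P cells (Homo sapiens) for antiproliferative activity, read by MTT assay, with a stated time of 48 h; on this read-out higher numbers stand for weaker inhibition and lower numbers for stronger inhibition:
Compound 1, `Nc1cccc2c(-c3cccc(NC(=O)c4nccs4)c3)ccnc12` — compound 1 gives 16700 nM.
Compound 2, `CC(=O)Nc1cccc2c(-c3cccc(NC(=O)c4cccc(C(F)(F)F)c4)c3)ccnc12` — compound 2 gives 8000 nM.
Compound 3, `CC(=O)Nc1cccc2c(-c3cccc(NC(=O)c4ccc(Cl)cc4C(F)(F)F)c3)ccnc12` — compound 3 is reported only as > 20000 nM, which is a limit of this assay and not a number.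

Compound 3 thus stands at the weak end of the values shown; it sits at the limit of > 20000 nM in this assay, at which 1 of the 3 values shown sits, so its place relative to compound 1 can only be given as not stronger than the others. Among the compounds with values here, the one single-point step measured on the amide side is an at least 2.5-fold higher number from compound 2 to compound 3 (0.39 log units; beyond the scatter), a weakening beyond the scatter.

Compound 4, `CC(=O)Nc1cccc2c(-c3cccc(NC(=O)c4nccs4)c3)ccnc12`, is not yet measured. Compared with compound 3 the change is 1,3-thiazol-2-yl in place of 4-chloro-2-(trifluoromethyl)phenyl on a carbonyl carbon. Within the data shown here, compound 1 carries the same 1,3-thiazol-2-yl amide and differs from compound 4 only at the amine on the core, where compound 4 carries the acetamide of compound 2 and compound 3; no step between compound 1 and compound 4 is measured, so compound 1 serves only as a rough anchor. Since compound 3 is known only as a limit, the step from compound 3 to compound 4 can be given only as a lower bound in direction.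

Compound 4 is therefore expected near 12000 nM, within 5000 nM to 30000 nM, which is an estimated step of an at least 1.6-fold lower number from compound 3 to compound 4 (0.22 log units; that floor lies within the scatter).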

Compound 4, half-maximal inhibitory concentration: > 20000 nM
Compound 4 gave a limit, no number; the forecaster's own chance of this, stated with the estimate: 25%; at least 1.6-fold (0.22 log units) between middle value and limit.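

In this assay compound 4 is reported only as > 20000 nM, a limit and not a number, so 1,3-thiazol-2-yl on this carbonyl carbon gives no readable activity, as with 4-chloro-2-(trifluoromethyl)phenyl: the limit of > 20000 nM in this assay, at which 2 of the 4 values shown sit.

Two quite different replacements of 3-(trifluoromethyl)phenyl, a six-membered aromatic ring of carbon only and a five-membered aromatic ring with 2 hetero atoms, now both lose activity, the second with an at least 2.5-fold higher number from compound 2 to compound 4 (0.39 log units; beyond the scatter). For acetyl in place of hydrogen on the nitrogen on an aromatic ring, the result is an at least 1.1-fold higher number from compound 1 to compound 4 (0.07 log units; that floor lies within the scatter), so no effect of that change can be claimed; the step between compound 3 and compound 4 cannot be read, since both are limits.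

From the compounds shown here alone, how far compound 3 and compound 4 lie beyond the limit stays open, and with it any order among the weak amides. Also open, going by these compounds, is whether an unsubstituted phenyl, a pyridin-3-yl or a 3-methoxyphenyl on the carbonyl carbon would hold the activity of compound 2, and what a free amine on the core would do alongside 3-(trifluoromethyl)phenyl.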